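Azido to chloro on the cyclopropane-fused sugar arm

A few compounds are considered here, and "the series" means these few. Any claim that something is new, unique, unknown or untested is made for them only; others in the source may bear on it.

Measured in an ADME assay on Vero 76 cells (Chlorocebus sabaeus) for cytotoxicity, read by neutral red uptake; on this read-out lower numbers stand for higher toxicity in this test and higher numbers for lower toxicity in this test:
- compound 1 `NCCNC(=O)[C@@]12C[C@@H]1[C@@H](n1cnc3c(NC(C4CC4)C4CC4)nc(Cl)nc31)[C@H](O)[C@@H]2O`: 50000 nM
- compound 2 `CC(C)[C@@H](Nc1nc(Cl)nc2c1ncn2[C@H]1[C@H](O)[C@H](O)[C@]2(CN=[N+]=[N-])C[C@H]12)C1CC1`: 32000 nM
- compound 3 `O[C@@H]1[C@H](O)[C@@H]2C[C@@H]2[C@H]1n1ccc2c(NC(C3CC3)C3CC3)nc(I)nc21`: 44000 nM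

The three measured compounds sit close together in this assay. Compound 2 carries the lowest of the three numbers, but its gap to compound 3 and its gap to compound 1 are both within the usual scatter of the measurement, so no ranking among them is supported by these data.

Compound 4 `CC(C)[C@@H](Nc1nc(Cl)nc2c1ncn2[C@H]1[C@H](O)[C@H](O)[C@]2(CCl)C[C@H]12)C1CC1` is not yet measured. It differs from compound 2 in one place: chloro in place of azido on a saturated chain carbon bound to a saturated ring carbon. The azido group is replaced by a chloro group on the saturated chain carbon bound to the saturated ring carbon; the rest of the structure, including the substituted core and the diol, is unchanged.

Within the data shown here, no measured pair in this set isolates the effect of such a change, so the step from compound 2 to compound 4 in this assay is expected to be small, without a clear direction, and likely inside the scatter, as a 1.1-fold higher number from compound 2 to compound 4 (0.04 log units; within the scatter). Compound 4 is therefore expected to give about 35000 nM, with a plausible range from 15000 nM to 80000 nM.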

Compound 4, half-maximal cytotoxic concentration: 27000 nM
Compound 4: middle estimate off by 1.3-fold (0.11 log units), on the high side; the range from low to high includes it.
By their numbers in this assay, from the lowest: compounds 4, 2, 3 and 1 (each within the scatter of the next).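

In this assay, among these compounds, the only one-place comparison reads a 1.2-fold lower number from compound 2 to compound 4 (0.07 log units; within the scatter). On a saturated chain carbon bound to a saturated ring carbon, azido and chloro therefore cannot be told apart in this read-out, at least with the rest of compound 2 held constant. The earlier compounds shown here differed from one another in several places and could not isolate this position, and no supporting data bear on this result.

On these data alone, it remains open whether an amine or a carboxylic acid in place of the chloro, or a longer chain at the same place, would also stay within the scatter of compound 2. Also open, as far as these compounds go, is whether azidomethyl to chloromethyl reads the same when other substituents sit on the shared core.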